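The source may report more compounds than this note shows. Statements on the series, on what has been measured and on what is new or still open speak of the compounds shown alone.

Measured compounds:
Compound 1 `Cc1ccc(NC2=CC(=O)c3c(nc4n3[C@H]3OC[C@@H](O)[C@H]3OC4)C2=O)cc1C`: 1050 nM
Compound 2 `COc1cccc(NC2=CC(=O)c3nc4n(c3C2=O)[C@H]2OC[C@@H](O)[C@H]2OC4)c1`: 1780 nM
Compound 3 `COc1ccc(NC2=CC(=O)c3nc4n(c3C2=O)[C@H]2OC[C@@H](O)[C@H]2OC4)cc1`: 1680 nM

The three values above were obtained in a functional assay on MGC-803 cells (Homo sapiens) for inhibition, read by sulforhodamine B assay; a higher number here means a weaker inhibitor, a lower number a stronger inhibitor. On these numbers compound 1 gives 1050 nM, compound 3 gives 1680 nM and compound 2 gives 1780 nM, and the gaps between the three all lie within the scatter. For the measured compounds named here, the only measured step between compounds that differ in one place, a 1.1-fold lower number from compound 2 to compound 3 (0.03 log units; within the scatter), was within the scatter, so the three compounds are effectively indistinguishable in this assay.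

Compound 4 `CCc1ccc(NC2=CC(=O)c3c(nc4n3[C@H]3OC[C@@H](O)[C@H]3OC4)C2=O)cc1` is not yet measured. It differs from compound 1 by 4-ethylphenyl in place of 3,4-dimethylphenyl on an amine nitrogen. Going by the values given here, no measured step addresses this rearrangement of the same atoms on the aryl ring attached to the amine nitrogen; the one step available, a move of a methoxy group, was within the scatter. In this assay the step from compound 1 to compound 4 is therefore expected to be small, a 1.1-fold higher number from compound 1 to compound 4 (0.06 log units; within the scatter), without a clear direction. Compound 4 is estimated at 1200 nM, within a range from 500 nM to 3000 nM.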

Compound 4, half-maximal inhibitory concentration: 1110 nM
Estimate against measurement, compound 4: 1.1-fold (0.03 log units) above; low and high end bracket the measured number.
By their numbers in this assay, from the lowest: compounds 1, 4, 3 and 2 (each within the scatter of the next).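

In this assay, 4-ethylphenyl in place of 3,4-dimethylphenyl on the amine nitrogen gave a 1.1-fold higher number from compound 1 to compound 4 (0.02 log units; within the scatter) and so left the number unchanged within the scatter, although the carbon atoms of the aryl group were joined differently. The earlier compounds shown here offered only the shift of a methoxy group, a 1.1-fold lower number from compound 2 to compound 3 (0.03 log units; within the scatter) and also within the scatter, whereas this step shows the same outcome for a rearrangement of alkyl substituents that keeps all eight carbons of the group. No independent measurement bears on this result, so what lies behind it stays unexplained.

Still open, on these data alone, is whether a carboxylic acid, an amine or a longer chain such as butyl on this aryl ring would move the number beyond the scatter. Also open, as far as these compounds go, is whether cyclohexyl could replace the aryl ring on the amine nitrogen without such a shift.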